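Aryl pattern on the ring amine nitrogen, A3 displacement

The source may report more compounds than this note shows. Statements on the series, on what has been measured and on what is new or still open speak of the compounds shown alone.

Values in an assay on CHO cells for displacement of a labelled ligand from adenosine receptor A3 (Homo sapiens), read by scintillation counting, with a stated time of 120 min, tested at 10 uM; a higher number here means more inhibition at the concentration tested (going by the name of the read-out), a lower number less inhibition:
compound 1 `CC(C)N1CCN(Cc2csc(N)c2C(=O)c2ccc(Cl)cc2)CC1`: 0%
compound 2 `Nc1scc(CN2CCN(c3ccc(F)cc3Cl)CC2)c1C(=O)c1ccc(Cl)cc1`: 0%
compound 3 `Nc1scc(CN2CCN(c3ccccc3F)CC2)c1C(=O)c1ccc(Cl)cc1`: 0%

Among the compounds with values here, compound 2 stands level with compounds 1 and 3; the steps of no change at the digits printed from compound 1 to compound 2 (within the scatter), no change at the digits printed from compound 1 to compound 3 (within the scatter) and no change at the digits printed from compound 2 to compound 3 (within the scatter) all lie within the scatter, so no member of the set separates from the others.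

Compound 4 `Nc1scc(CN2CCN(c3ccc(F)c(Cl)c3)CC2)c1C(=O)c1ccc(Cl)cc1` differs from compound 2 by 3-chloro-4-fluorophenyl in place of 2-chloro-4-fluorophenyl on an amine nitrogen in a ring. The step from compound 2 to compound 3, a change of the aryl group on the same ring amine nitrogen, bears most directly on this and gave no change. Replacing the isopropyl of compound 1 by either aryl group likewise gave no change. The expected step is therefore no change at the digits printed from compound 2 to compound 4 (within the scatter), none beyond the scatter. For compound 4 the estimate in this assay is 0%, within -5% to 15%.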

Compound 4, a percentage reported as inhibition, at one concentration (the size of the read-out at that concentration, not a potency): 0%
Compound 4: middle estimate and measured number agree at the digits printed; the range from low to high includes it.
By their numbers in this assay, from the lowest: compounds 1, 2, 3 and 4 (each within the scatter of the next).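

In this assay, 3-chloro-4-fluorophenyl in place of 2-chloro-4-fluorophenyl on the amine nitrogen in the ring gives no change at the digits printed from compound 2 to compound 4 (within the scatter), so a pair with the same atoms joined differently does not separate here either. The other two comparisons agree: no change at the digits printed from compound 3 to compound 4 (within the scatter) and no change at the digits printed from compound 1 to compound 4 (within the scatter). Nothing available explains this result.

The compounds shown leave open whether a benzyl or pyridyl group on this nitrogen would separate from these four. Also open, on these data alone, is whether an amide in place of the ring amine would do so.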